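A few compounds are considered here, and "the series" means these few. Any claim that something is new, unique, unknown or untested is made for them only; others in the source may bear on it.

Measured so far:
- compound 1 `Nc1sc(-c2ccc(Cl)cc2)c(-c2ccc(Cl)cc2)c1C(=O)NC1CCCC1`: 21200 nM
- compound 2 `COC(=O)c1c(N)sc(-c2ccc(Cl)cc2)c1-c1ccc(Cl)cc1`: 2780 nM
- compound 3 `CC1CCN(C(=O)c2c(N)sc(-c3ccc(Cl)cc3)c2-c2ccc(Cl)cc2)CC1`: 5750 nM

In a functional assay on PC-3 cells (Homo sapiens) for inhibition, read by sulforhodamine B assay, with a stated time of 72 h (on this read-out lower numbers stand for stronger inhibition and higher numbers for weaker inhibition), compound 1 stands with the highest of the three numbers, that is the weakest inhibition of the set; the nearest is compound 3 and the furthest is compound 2. Both measured steps away from compound 1 change the group on the carbonyl carbon and both lower the number: a 7.6-fold lower number from compound 1 to compound 2 (0.88 log units; beyond the scatter) and a 3.7-fold lower number from compound 1 to compound 3 (0.57 log units; beyond the scatter). Between those two, a 2.1-fold higher number from compound 2 to compound 3 (0.32 log units; beyond the scatter).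

Compound 4 `Nc1sc(-c2ccc(Cl)cc2)c(-c2ccc(Cl)cc2)c1C(=O)N1CCOCC1` is not yet measured in this assay. Compared with compound 1, (morpholin-4-yl in place of cyclopentylamino on a carbonyl carbon). Within the data shown here, the step that bears on it most is the one from compound 1 to compound 3, where a six-membered non-aromatic ring with no hydrogen-bond donor likewise replaced cyclopentylamino on the carbonyl carbon and gave a modest lowering; the step to compound 2 points the same way. Among the measured compounds shown here, a modest lowering of the number is therefore expected for compound 4, comparable to that seen for compound 3, although only two steps support this. The expected step is a 3.0-fold lower number from compound 1 to compound 4 (0.48 log units; beyond the scatter). Compound 4 is estimated at 7000 nM, within a range of 2500 nM to 20000 nM.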

Compound 4, half-maximal inhibitory concentration: 11700 nM
Compound 4: middle estimate off by 1.7-fold (0.22 log units), on the low side; the range from low to high includes it.
By their numbers in this assay, from the lowest: compound 2; then compound 3; then compounds 4 and 1 (each within the scatter of the next).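

In this assay, among these compounds, the step to morpholin-4-yl on the carbonyl carbon (a 1.8-fold lower number from compound 1 to compound 4 (0.26 log units; within the scatter)) is the first replacement of cyclopentylamino that stays within the scatter, so a change at this position need not move the number away from that of compound 1. The two six-membered rings also part company (a 2.0-fold higher number from compound 3 to compound 4 (0.31 log units; beyond the scatter)): leaving out the amide hydrogen, as both of them do, does not fix the outcome, and the ring itself counts here, with morpholin-4-yl and 4-methylpiperidin-1-yl giving a measurable gap. Methoxy keeps its lead over the new amide (a 4.2-fold higher number from compound 2 to compound 4 (0.62 log units; beyond the scatter)), and compound 2 remains the strongest inhibitor of the four, with all its steps beyond the scatter.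

No data at hand explain the gap between the two rings. Still open, as far as these compounds go, is whether piperidin-1-yl without the methyl, a piperazine, an ethoxy ester or a carboxylic acid on the same carbonyl carbon would fall with methoxy or with the amides.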